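Replacing 2-Methylphenyl with 3-Nitrophenyl on the Shared Core

The source may report more compounds than this note shows. Statements on the series, on what has been measured and on what is new or still open speak of the compounds shown alone.

Three compounds share one core and differ only in the group carried on the nitrogen attached to the aromatic ring. Compound 1 `C=CC(=O)Nc1cccc(NC(=O)CSc2nc(Nc3ccccc3F)c3ccccc3n2)c1` gives 6580 nM in a functional assay on NCI-H1975 cells (Homo sapiens) for inhibition, read by MTT assay, with a stated time of 72 h; on this read-out higher numbers stand for weaker inhibition and lower numbers for stronger inhibition. Compound 2 `C=CC(=O)Nc1cccc(NC(=O)CSc2nc(Nc3ccccc3Br)c3ccccc3n2)c1` gives 19300 nM in this assay, and compound 3 `C=CC(=O)Nc1cccc(NC(=O)CSc2nc(Nc3ccccc3C)c3ccccc3n2)c1` gives 9920 nM in this assay. Compound 3 thus stands second highest of the three numbers; its nearest neighbour is compound 1, with a 1.5-fold higher number from compound 1 to compound 3 (0.18 log units; within the scatter), and its furthest is compound 2, with a 1.9-fold lower number from compound 2 to compound 3 (0.29 log units; within the scatter). For the measured compounds named here, the only step that goes beyond the scatter is a 2.9-fold higher number from compound 1 to compound 2 (0.47 log units; beyond the scatter).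

Compound 4 `C=CC(=O)Nc1cccc(NC(=O)CSc2nc(Nc3cccc([N+](=O)[O-])c3)c3ccccc3n2)c1` has not yet been measured. It differs from compound 3 in one place: 3-nitrophenyl in place of 2-methylphenyl on a nitrogen on an aromatic ring. Going by the values given here, none of the measured steps involves a nitro group; all three stay among the fluoro, bromo and methyl variants on the same aromatic carbon, and even the largest of them, a 2.9-fold higher number from compound 1 to compound 2 (0.47 log units; beyond the scatter), is only modest. The expectation for compound 4 is therefore a step of modest size at most in this assay, with no clear direction, and quite possibly none beyond the scatter. The estimated step is a 1.1-fold lower number from compound 3 to compound 4 (0.04 log units; within the scatter). Compound 4 is expected to give about 9000 nM in this assay, within a range from 3000 nM to 30000 nM.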

Compound 4, half-maximal inhibitory concentration: 22600 nM
Compound 4: the middle estimate sits 2.5-fold (0.40 log units) below what was measured, and the stated range covers the measured number.
By their numbers in this assay, from the lowest: compounds 1, 3, 2 and 4 (each within the scatter of the next, the first and the last beyond it).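

Placing a 3-nitrophenyl group on this nitrogen takes the series outside the fluoro, bromo and methyl variants, and in this assay it gives a 2.3-fold higher number from compound 3 to compound 4 (0.36 log units; beyond the scatter) and a 3.4-fold higher number from compound 1 to compound 4 (0.54 log units; beyond the scatter) so that both steps pass beyond the scatter while remaining modest. Against the 2-bromophenyl group the same change gives a 1.2-fold higher number from compound 2 to compound 4 (0.07 log units; within the scatter) and so does not separate these two compounds, which shows that this position tolerates a change in both the group and its place on the ring with no gain in inhibition over compound 1 or compound 3. Nothing available bears on why these steps take this size.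

The compounds shown leave open whether the nitro group itself or its place on the ring sets the step, and a 2-nitrophenyl or a 3-methylphenyl partner would separate the two. Also open, from the compounds shown here alone, is how this assay would respond to an amine or a carboxylic acid on this ring.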